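A larger group on the carbonyl of compound 2

A few compounds are considered here, and "the series" means these few. Any claim that something is new, unique, unknown or untested is made for them only; others in the source may bear on it.

Of the compounds shown here, three have been measured so far in a physicochemical assay for lipophilicity, measured as octanol-water partition, at pH 7.4; on this read-out lower numbers stand for lower lipophilicity and higher numbers for higher lipophilicity. Compound 1 (`Cc1ccc2[nH]c(C(=O)N[C@H]3CCN(S(=O)(=O)N4CCCCC4)C[C@@H]3C(=O)NCCN(C)C)cc2c1`) gives 2.3. Compound 3 (`Cc1oc(-c2ccc(Cl)cc2)nc1C(=O)N[C@H]1CN(S(=O)(=O)c2ccccc2)C[C@@H]1C(=O)N[C@H]1CCCNC1`) gives 2, within the scatter of the value for compound 1. Compound 2 (`Cc1csc(C(=O)N[C@H]2CN(S(=O)(=O)c3ccccc3)C[C@@H]2C(=O)N[C@H]2CCCNC2)n1`) gives 0.1, the lowest of the three numbers and beyond the scatter from both of the others.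

Compound 4 (`O=C(N[C@H]1CN(S(=O)(=O)c2ccccc2)C[C@@H]1C(=O)N[C@H]1CCCNC1)c1cc(-c2ccc(Cl)cc2)on1`) departs from compound 2 in one place, with 5-(4-chlorophenyl)-1,2-oxazol-3-yl in place of 4-methyl-1,3-thiazol-2-yl on a carbonyl carbon. Among the measured compounds shown here, no measured pair of compounds shows a step for a change in one place, so any forecast here is indirect. The closest guide is compound 3, which also bears a 4-chlorophenyl group and gives 2. On that single comparison, a rise beyond the scatter is expected in this assay, with the size estimated as a number 1.70 log units higher from compound 2 to compound 4 (beyond the scatter). This rests on one compound only, and compound 3 is not the same structure as compound 4, so the range is kept wide. For compound 4 the expected value is 1.8, with an estimated range from 1.3 to 2.3.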

Compound 4, distribution coefficient: 2.1
Compound 4: the middle estimate sits 0.30 log units below what was measured; low and high end bracket the measured number.
By their numbers in this assay, from the lowest: compound 2; then compounds 3, 4 and 1 (each within the scatter of the next).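

Among the compounds shown here, this is the first step that changes one place alone, and it shows that the group on this carbonyl carbon can carry a large shift in this assay: 5-(4-chlorophenyl)-1,2-oxazol-3-yl in place of 4-methyl-1,3-thiazol-2-yl gives a number 2.00 log units higher from compound 2 to compound 4 (beyond the scatter) with the rest of the structure unchanged. The change keeps one five-membered aromatic ring with 2 hetero atoms, leaves the counts of hydrogen-bond donors and acceptors as they were, and involves no net charge on either group, while the entering group adds a six-membered aromatic ring of carbon only and has 12 heavy atoms against 6. No measurement given here accounts for the size of this step.

The step replaces the whole group at once, so the compounds shown do not separate the contribution of the added ring, the chlorine and the exchange of one five-membered ring for the other. A 5-phenyl-1,2-oxazol-3-yl group, lacking only the chlorine, or a 5-methyl-1,2-oxazol-3-yl group, lacking the whole chlorophenyl ring, at this place would begin to divide the step into its parts.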